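The source may report more compounds than this note shows. Statements on the series, on what has been measured and on what is new or still open speak of the compounds shown alone.

Compound 1 `CN(C)/C=N/c1c(C=O)c(-c2ccccc2)nn1-c1ccccc1` carries a formyl group on its core, and compound 3 `CN(C)/C=N/c1cc(-c2ccccc2)nn1-c1ccccc1` differs from it in one place: hydrogen in place of formyl on an aromatic carbon. In a functional assay on NCI-H226 cells (Homo sapiens) for inhibition, read by MTT assay, with a stated time of 72 h (on this read-out lower numbers stand for stronger inhibition of growth and higher numbers for weaker inhibition of growth), compound 1 gives 31400 nM. For compound 3 this assay reports only a limit, > 100000 nM, not a number. The step is therefore an at least 3.1-fold higher number from compound 1 to compound 3 (0.50 log units; beyond the scatter), and its true size is known only as a lower bound because of the limit of > 100000 nM in this assay, at which 1 of the 3 values shown sits.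

Compound 2 `Cc1ccc(-c2nn(-c3cccc(Cl)c3)c(/N=C/N(C)C)c2C=O)cc1` carries the same formyl group on another core; how the core of compound 2 differs from that of compound 1 is not broken down here. In this assay compound 2 gives 8900 nM, the lower of the two numbers seen so far. Compound 4 `Cc1ccc(-c2cc(/N=C/N(C)C)n(-c3cccc(Cl)c3)n2)cc1` stands to compound 2 as compound 3 stands to compound 1: hydrogen in place of formyl on an aromatic carbon. This is the same kind of change, not the same one, since the surroundings differ: in compound 1 the carbon sits next to the ring atom that bears a phenyl group and two ring bonds from the ring atom that bears a phenyl group, whereas in compound 2 it sits next to the ring atom that bears a 4-methylphenyl group and two ring bonds from the ring atom that bears a 3-chlorophenyl group.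

Because the step of an at least 3.1-fold higher number from compound 1 to compound 3 (0.50 log units; beyond the scatter) came from the same kind of change, a loss of similar size is expected for compound 4, namely a 4.5-fold higher number from compound 2 to compound 4 (0.65 log units; beyond the scatter). Compound 4 is thus estimated at 40000 nM, most likely between 15000 nM and 120000 nM, with a real chance that this assay again reports only a limit.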

Compound 4, concentration for 50% growth inhibition: 80900 nM
For compound 4 the middle estimate is 2.0-fold (0.31 log units) below the measured one; measured number inside the range.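

On the core of compound 2, putting hydrogen in place of the formyl group gives a 9.1-fold higher number from compound 2 to compound 4 (0.96 log units; beyond the scatter) in this assay, so growth inhibition weakens here as it did on the core of compound 1. Set side by side, the two pairs show that the direction of the change carries over between these two cores, but they do not settle whether its size carries over as well: the same change on two cores in this assay, an at least 3.1-fold higher number (0.50 log units; beyond the scatter) from compound 1 to compound 3 and a 9.1-fold higher number (0.96 log units; beyond the scatter) from compound 2 to compound 4; the limit leaves it open whether they differ. Two pairs also cannot show that every core in this series would respond in the same way, and the size of the step on the first core stays unsettled, as compound 3 is reported only as a limit: the limit of > 100000 nM in this assay, at which 1 of the 4 values shown sits.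

The compounds shown hold only formyl or hydrogen on this aromatic carbon, so it remains open how a nitrile, a carboxylic acid, a hydroxymethyl group or an amine in that place would behave in this assay. The two cores also differ in both of their aromatic substituents at once, which leaves open what the 4-methylphenyl group and the 3-chlorophenyl group each contribute on their own.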